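The source may report more compounds than this note shows. Statements on the series, on what has been measured and on what is new or still open speak of the compounds shown alone.

Compound 1 `O=C1/C(=C/c2ccccc2Br)CCc2ccccc21` is the weaker of the two measured compounds: in a functional assay on CCRF-CEM cells (Homo sapiens) for inhibition (on this read-out lower numbers stand for stronger inhibition and higher numbers for weaker inhibition), compound 1 gives 25400 nM. Among the compounds with values here, the only other measured compound, compound 2 `O=C1/C(=C/c2ccc(Cl)c(Cl)c2)CCc2ccccc21`, gives 9770 nM in this assay, a lower number that lies beyond the scatter from compound 1. Within the data shown here, no pair differing in one place has been measured, so the series gives no step to lean on. Compound 3 `Cc1ccccc1/C=C1\CCc2ccccc2C1=O` differs from compound 1 by methyl in place of bromo on an aromatic carbon. The step from compound 1 to compound 3 is expected to be small, a 1.2-fold lower number from compound 1 to compound 3 (0.06 log units; within the scatter), within the scatter in either direction. Compound 3 is estimated at 22000 nM, with a range of 7000 nM to 70000 nM.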

Compound 3, half-maximal inhibitory concentration: 43200 nM
For compound 3 the middle estimate is 2.0-fold (0.29 log units) below the measured one, and the stated range covers the measured number.
By their numbers in this assay, from the lowest: compound 2; then compounds 1 and 3 (each within the scatter of the next).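

Methyl in place of bromo on an aromatic carbon, ortho to a large group, gives a 1.7-fold higher number from compound 1 to compound 3 (0.23 log units; within the scatter) in this assay and leaves the two groups indistinguishable at this position. Within the data shown here, as the first single-place step, it shows that this exchange produces no shift beyond the scatter. Nothing at hand explains this reading.

As far as these compounds go, whether a hydroxyl, an amine or a carboxylic acid at this position would move the number beyond the scatter stays open. So does whether the same exchange would read alike elsewhere on this ring.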